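The source may report more compounds than this note shows. Statements on the series, on what has been measured and on what is new or still open speak of the compounds shown alone.

Measured compounds:
Compound 1, `Cc1nc(N)c2c(-c3ccccc3)cn([C@@H]3O[C@H](CO)[C@@H](O)[C@H]3O)c2n1` — in a functional assay on A549 cells (Homo sapiens), read by MTT assay, with a stated time of 72 h (on this read-out lower numbers stand for stronger inhibition and higher numbers for weaker inhibition), compound 1 gives > 20000 nM, which is a limit of the assay rather than a number.
Compound 2, `C#Cc1cn([C@@H]2O[C@H](CO)[C@@H](O)[C@H]2O)c2ncnc(NC)c12` — in this assay compound 2 gives > 20000 nM, again a limit.
Compound 3, `Nc1nc(N)c2c(-c3ccccc3)cn([C@@H]3O[C@H](CO)[C@@H](O)[C@H]3O)c2n1` — in this assay compound 3 gives > 20000 nM, also a limit.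

Compound 1 therefore stands at the limit, with no number of its own; the other two values shown sit at the same limit, as the limit of > 20000 nM in this assay, at which 3 of the 3 values shown sit, records. Among the compounds with values here, the one measured step that touches compound 1, a step that the two limits leave unreadable from compound 1 to compound 3, cannot be read in size because both ends are limits.

Compound 4, `Cc1nc(N)c2c(-c3ccsc3)cn([C@@H]3O[C@H](CO)[C@@H](O)[C@H]3O)c2n1`, has not yet been measured. It differs from compound 1 in one place: thiophen-3-yl in place of phenyl on an aromatic carbon. Within the data shown here, no measured step covers a change of this kind, so the step from compound 1 to compound 4 in this assay can only be guessed from where compound 1 stands. With every value shown sitting at the limit, compound 4 is expected to give a result near or at that same limit, 25000 nM, within 8000 nM to 80000 nM. The step this estimate means, a step that the limit leaves unreadable from compound 1 to compound 4, is expected to be none beyond the scatter.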

Compound 4, half-maximal inhibitory concentration: > 20000 nM
Compound 4: only a limit was reported; the forecaster's own chance of this, stated with the estimate: 80%; the middle value does not contradict the limit.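

Within the data shown here, compound 1 and compound 4 both give a limit of the assay rather than a number, so the change from phenyl to thiophen-3-yl yields no step that can be read in this assay. Compound 4 joins the other compounds there: the limit of > 20000 nM in this assay, at which 4 of the 4 values shown sit.

The compounds shown leave open how strongly any of them acts on these cells, and whether any single change in structure alters that.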